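Extending the propargyloxy chain: from compound 2 to compound 4

A few compounds are considered here, and "the series" means these few. Any claim that something is new, unique, unknown or untested is made for them only; others in the source may bear on it.

Three compounds of the series have numbers in an assay on isolated protein for inhibition of Aromatase (Homo sapiens), read by fluorescence, with stated times of 10 min and 60 min; a lower number here means a stronger inhibitor, a higher number a weaker inhibitor. Compound 1 `O=C(c1ccc(O)cc1)c1cccc(Cn2ccnc2)c1` gives 13 nM. Among the measured compounds shown here, compound 3 `CCC#CCOc1ccc(C(=O)c2cccc(Cn3ccnc3)c2)cc1` shares the core of compound 1; compound 3 gives 9 nM, and the step of a 1.4-fold lower number from compound 1 to compound 3 (0.16 log units; within the scatter) is the only single-point change measured so far. Compound 2 `C#CCOc1ccc(C(=O)c2ccc(Cn3ccnc3)cc2)cc1` gives 210 nM, the highest of the three numbers, beyond the scatter from compound 1 and further still from compound 3.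

Compound 4 `CCC#CCOc1ccc(C(=O)c2ccc(Cn3ccnc3)cc2)cc1` shares the core of compound 2. The change is ethyl in place of hydrogen on a triple-bonded carbon; read one bond further out it is propargyloxy to (pent-2-yn-1-yl)oxy. For the measured compounds named here, no measured pair isolates this change on either core. The step from compound 1 to compound 3, hydrogen to pent-2-yn-1-yl on the oxygen, contains it as a part and stayed within the scatter, so in this assay no step beyond the scatter is expected here either. The expected step of a 1.3-fold lower number from compound 2 to compound 4 (0.12 log units; within the scatter) is therefore estimated to fall within the scatter. Compound 4 is expected at 160 nM, with a range from 60 nM to 450 nM.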

Compound 4, half-maximal inhibitory concentration: 1430 nM
The estimate for compound 4 lay 8.9-fold (0.95 log units) below the measured number; the whole stated range lies below it.
By their numbers in this assay, from the lowest: compounds 3 and 1 (each within the scatter of the next); then compound 2; then compound 4.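

On the core of compound 2, ethyl in place of hydrogen on a triple-bonded carbon is not a silent change: in this assay it gives a 6.8-fold higher number from compound 2 to compound 4 (0.83 log units; beyond the scatter). The earlier step on the core of compound 1, a 1.4-fold lower number from compound 1 to compound 3 (0.16 log units; within the scatter), replaced hydrogen on the oxygen with the whole pent-2-yn-1-yl group and stayed within the scatter, so tolerance of that chain on one core does not carry over to the other. No available evidence bears on the cause of this loss.

The compounds shown leave open how the number changes with a methyl or a longer alkyl chain on the same triple-bonded carbon. They also leave open what the ethyl change does on the core of compound 1, where the propargyloxy counterpart of compound 3 is absent from this set.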